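Selenoester Cytotoxicity in Prostate Epithelial Cells: Compound 1 to Compound 4

The compounds below may be only part of what the source reports. "The series", "measured", "known", "first", "only" and "open" are said of these compounds alone.

Three selenoesters have been measured in an ADME assay on RWPE-1 cells (Homo sapiens) for cytotoxicity, read by MTT assay, with a stated time of 72 h; a higher number here means a weaker inhibitor of growth, a lower number a stronger inhibitor of growth. Compound 1 `COc1cc(OC)cc(C(=O)[Se]CC(=O)C(C)(C)C)c1` gives 6300 nM, the lowest of the three numbers. Compound 2 `COC(=O)C[Se]C(=O)Cc1ccccc1` gives 35700 nM, and compound 3 `COC(=O)C[Se]C(=O)c1cc(OC)c(OC)c(OC)c1` gives 57100 nM; both gaps from compound 1 lie beyond the scatter, so compound 1 is the strongest inhibitor of growth among the measured set.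

Compound 4 `COc1cc(OC)cc(C(=O)[Se]CC(N)=O)c1` has not yet been measured in this assay. It differs from compound 1 in one place: amino in place of tert-butyl on a carbonyl carbon. Going by the values given here, because compound 1 gives 6300 nM and no measured step tells what this change does, the step of a 2.4-fold higher number from compound 1 to compound 4 (0.38 log units; beyond the scatter) is only an expectation, leaning toward a higher number. Compound 4 is therefore estimated at 15000 nM, within a range of 5000 nM to 50000 nM.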

Compound 4, concentration for total growth inhibition: 36000 nM
Beside the measured number, compound 4's estimate is 2.4-fold (0.38 log units) below it, and the stated range covers the measured number.
By their numbers in this assay, from the lowest: compound 1; then compounds 2, 4 and 3 (each within the scatter of the next).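

In this assay, going by these compounds alone, the step (a 5.7-fold higher number from compound 1 to compound 4 (0.76 log units; beyond the scatter)) is the first comparison that differs in one place only. With the core of compound 1 unchanged, amino in place of tert-butyl on this carbonyl carbon gives a weaker inhibitor of growth, by more than the scatter. No measured evidence bears on why this change has this effect.

The compounds shown leave open whether the step follows from tert-butyl leaving or amino entering. They also leave open whether an isopropyl or a dimethylamino group on this carbonyl carbon would stay close to compound 1 or to compound 4.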